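Swapping the aryl substituent: from compound 2 to compound 3

This account rests on a few compounds, and the source may have more. Where it says the series, first, only, none or still open, it means among the compounds named here.

Compound 1 `CCCS(=O)(=O)Nc1ccc(F)c(C(=O)c2n[nH]c3ncc(-c4ccccc4O)cc23)c1F` gives 9% in an assay for binding affinity to dual specificity mitogen-activated protein kinase kinase 4 (Homo sapiens), read by KINOMEscan, tested at 100 nM; a higher number here means a weaker effect of the compound at the concentration tested, a lower number a stronger effect. Compound 2 `CCCS(=O)(=O)Nc1ccc(F)c(C(=O)c2n[nH]c3ncc(-c4cccc(N)c4)cc23)c1F` gives 1.6% in this assay, and the step of a number 7.4 percentage points lower from compound 1 to compound 2 (within the scatter) places the two within the scatter of each other, so compound 2 stands alongside compound 1 on these numbers. Compound 3 `CCCS(=O)(=O)Nc1ccc(F)c(C(=O)c2n[nH]c3ncc(-c4ccc(C(C)C)cc4)cc23)c1F` differs from compound 2 by 4-isopropylphenyl in place of 3-aminophenyl on an aromatic carbon. Going by the values given here, only the step from compound 1 to compound 2 bears on this place, and it stayed within the scatter, so in this assay a step of a number 6.4 percentage points higher from compound 2 to compound 3 (within the scatter) is expected, with no clear direction. Compound 3 is therefore estimated at 8%, within 1% to 35%.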

Compound 3, a percentage reported as activity, at one concentration (the size of the read-out at that concentration, not a potency): 17%
Estimate against measurement, compound 3: 9 percentage points below; measured number inside the range.
By their numbers in this assay, from the lowest: compounds 2, 1 and 3 (each within the scatter of the next, the first and the last beyond it).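

In this assay this position now shows a change beyond the scatter: a number 15.4 percentage points higher from compound 2 to compound 3 (beyond the scatter) when 4-isopropylphenyl, with no hydrogen-bond donor or acceptor, replaces 3-aminophenyl. Replacing the 2-hydroxyphenyl of compound 1 with the same group gives a number 8 percentage points higher from compound 1 to compound 3 (within the scatter) and so does not separate the two. No evidence at hand accounts for either step.

Since the amine leaves as the isopropyl enters, the compounds shown do not tell which of the two changes carries the larger step. Also open, as far as these compounds go, is what an unsubstituted phenyl or a phenyl bearing a carboxylic acid would give here.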